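The compounds below may be only part of what the source reports. "The series", "measured", "known", "first", "only" and "open" are said of these compounds alone.

Three compounds have been tested in a functional assay on HepG2 cells (Homo sapiens) for inhibition, read by MTT assay, with a stated time of 72 h; on this read-out lower numbers stand for stronger inhibition and higher numbers for weaker inhibition:

Compound 1, `COc1cccc(-n2cc(COc3cccc(NC(=O)Nc4ccc(Cl)c(C(F)(F)F)c4)c3)nn2)c1`, gives 1310 nM.
Compound 2, `N#Cc1cccc(-n2cc(COc3cccc(NC(=O)Nc4ccc(Cl)c(C(F)(F)F)c4)c3)nn2)c1`, gives 2760 nM.
Compound 3, `O=C(Nc1cccc(OCc2cn(-c3ccccc3F)nn2)c1)Nc1ccc(Cl)c(C(F)(F)F)c1`, gives 1520 nM.

All three share the same core and differ only in the aromatic group carried on a nitrogen of the five-membered ring. Compound 3 stands second highest of these three numbers; its nearest neighbour is compound 1, with a 1.2-fold higher number from compound 1 to compound 3 (0.06 log units; within the scatter), and its furthest is compound 2, with a 1.8-fold lower number from compound 2 to compound 3 (0.26 log units; within the scatter). Both gaps are within the scatter, so compound 3 cannot be separated from either. Within the data shown here, the only step that clears the scatter is a 2.1-fold higher number from compound 1 to compound 2 (0.32 log units; beyond the scatter), which changes a group on the aromatic ring rather than the whole ring itself.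

Compound 4, `O=C(Nc1cccc(OCc2cn(-c3ccc(F)cc3)nn2)c1)Nc1ccc(Cl)c(C(F)(F)F)c1`, differs from compound 3 by 4-fluorophenyl in place of 2-fluorophenyl on an aromatic nitrogen. This resembles the two earlier swaps of the aromatic group on the ring nitrogen, both of which stayed within the scatter. On that basis the expected step is small, with no direction beyond the scatter: a 1.0-fold lower number from compound 3 to compound 4 (0.01 log units; within the scatter). Compound 4 is therefore estimated at 1500 nM in this assay, with a likely range from 700 nM to 3200 nM.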

Compound 4, half-maximal inhibitory concentration: 1350 nM
Compound 4: the middle estimate sits 1.1-fold (0.05 log units) above what was measured, within the range that was stated.
By their numbers in this assay, from the lowest: compounds 1, 4, 3 and 2 (each within the scatter of the next, the first and the last beyond it).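

In this assay, among these compounds, the two fluorinated compounds carry the same atoms joined differently, and 4-fluorophenyl in place of 2-fluorophenyl gives a 1.1-fold lower number from compound 3 to compound 4 (0.05 log units; within the scatter) as the result, so this is the first direct sign that moving the fluorine around this phenyl ring leaves no readable change here; the earlier swaps all changed the group itself. The step of a 1.0-fold higher number from compound 1 to compound 4 (0.01 log units; within the scatter) also leaves 4-fluorophenyl and 3-methoxyphenyl indistinguishable, while the step of a 2.0-fold lower number from compound 2 to compound 4 (0.31 log units; beyond the scatter) is modest but clears the scatter, so 3-cyanophenyl now stands apart from two other groups, although compound 3 goes against this by staying within the scatter of compound 2. Nothing measured here accounts for any of these numbers.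

Every group shown on the ring nitrogen is a substituted phenyl ring, so it remains open whether a saturated ring such as cyclohexyl or a plain alkyl chain would be tolerated at this position in the same way. On these data alone, it is equally open whether an amine or a carboxylic acid on that phenyl ring would move the number further than the groups seen so far.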